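Iodo in Place of Thiophen-3-yl: Expected Cytotoxicity of Compound 3

The source may report more compounds than this note shows. Statements on the series, on what has been measured and on what is new or still open speak of the compounds shown alone.

Measured compounds:
Compound 1 `Cc1cc(-c2cccc(F)c2)c2ncc(CSCCc3ccccc3)n2c1`: 20 ug/mL
Compound 2 `Cc1cc(-c2ccsc2)cn2c(CSCCc3ccccc3)cnc12`: >= 4 ug/mL

Of the compounds shown here, two have been measured in an ADME assay on HEL cells (Homo sapiens) for cytotoxicity, with a stated time of 3 days; on this read-out higher numbers stand for lower toxicity in this test and lower numbers for higher toxicity in this test. Compound 1 `Cc1cc(-c2cccc(F)c2)c2ncc(CSCCc3ccccc3)n2c1` gives 20 ug/mL in this assay. For compound 2 `Cc1cc(-c2ccsc2)cn2c(CSCCc3ccccc3)cnc12` the read-out in this assay is a limit of the assay rather than a number, >= 4 ug/mL. Where compound 2 stands on the numbers is therefore known only through (the limit of >= 4 ug/mL in this assay, at which 1 of the 2 values shown sits), so its position relative to compound 1 cannot be read off.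

Compound 3 `Cc1cc(I)cn2c(CSCCc3ccccc3)cnc12` has not yet been measured in this assay. It differs from compound 2 in one place: iodo in place of thiophen-3-yl on an aromatic carbon. No step between two measured compounds is available, so the shown data give no measured size for what such a swap does in this assay; any expectation must rest on the two values alone, one of them a limit.

On that footing, compound 3 is estimated at 20 ug/mL in this assay, within an expected range from 4 ug/mL to 100 ug/mL. That estimate corresponds to an expected step that the limit leaves unreadable from compound 2 to compound 3, a change not expected to exceed the usual scatter in a clear direction.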

Compound 3, minimum cytotoxic concentration: >= 0.8 ug/mL
Compound 3: only a limit was reported (the forecaster's own chance of this, stated with the estimate: 40%); the middle value does not contradict the limit.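

In this assay compound 3 gives >= 0.8 ug/mL, which is a limit of the assay and not a number. Among the compounds shown here, compound 2 is also reported only as a limit, so no step between compound 2 and compound 3 can be read. From the compounds shown here alone, what iodo in place of thiophen-3-yl does to this read-out remains open.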